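Trifluoromethyl for fluoro on the aryl ring of compound 2

A few compounds are considered here, and "the series" means these few. Any claim that something is new, unique, unknown or untested is made for them only; others in the source may bear on it.

Compound 1 `CCCCc1nc(C(=O)OC)nn1-c1ccc(F)cc1` is reported in a functional assay on NPC-TW01 cells (Homo sapiens) for inhibition, read by MTT assay, with a stated time of 72 h (on this read-out lower numbers stand for stronger inhibition of growth and higher numbers for weaker inhibition of growth), only as a limit, > 100000 nM, not as a number. Compound 2 `COC(=O)c1nc(C2CCCCC2)n(-c2ccc(F)cc2)n1` gives 30500 nM in this assay, and compound 3 `COC(=O)c1nc(-c2ccccc2)n(-c2ccc(F)cc2)n1` gives 15600 nM. Of these two numbers, compound 2 holds the higher, yet the gap is small, as shown by a 2.0-fold lower number from compound 2 to compound 3 (0.29 log units; within the scatter). The measured steps, an at least 3.2-fold lower number from compound 1 to compound 2 (0.51 log units; beyond the scatter) and an at least 6.4-fold lower number from compound 1 to compound 3 (0.80 log units; beyond the scatter), each exchange the group on an aromatic carbon of the shared core and leave the fluoro-bearing ring untouched. Compound 4 `COC(=O)c1nc(C2CCCCC2)n(-c2ccc(C(F)(F)F)cc2)n1` differs from compound 2 by trifluoromethyl in place of fluoro on an aromatic carbon. Among the measured compounds shown here, no measured step alters this ring, so no change beyond the scatter is expected in this assay. Compound 4 is estimated at 30000 nM, between 10000 nM and 90000 nM. This estimate corresponds to an expected 1.0-fold lower number from compound 2 to compound 4 (0.01 log units; within the scatter).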

Compound 4, concentration for 50% growth inhibition: > 100000 nM
Compound 4 was reported as a limit; the forecaster's own chance of this, stated with the estimate: 12%; at least 3.3-fold (0.52 log units) between middle value and limit.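

The earlier steps shown here left the aryl ring untouched; this one shows that the group on it matters in this assay, with trifluoromethyl in place of fluoro giving an at least 3.2-fold higher number from compound 2 to compound 4 (0.51 log units; beyond the scatter). A higher number here means weaker inhibition of growth, so this position does not accept the larger group without loss. The value of compound 4, > 100000 nM, is a limit and not a number, so the step gives only a minimum size: the limit of > 100000 nM in this assay, at which 2 of the 4 values shown sit.

On these data alone, whether chloro, methoxy or an amine at this place would stay close to compound 2 or fall away like compound 4 remains open. Also open, as far as these compounds go, is whether the same exchange would weaken compound 3, which carries phenyl instead of cyclohexyl.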